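A few compounds are considered here, and "the series" means these few. Any claim that something is new, unique, unknown or untested is made for them only; others in the source may bear on it.

Compound 1 `O=C(NCc1ccc(S(=O)(=O)c2cncc(C(F)(F)F)c2)cc1)N1Cc2ccncc2C1`: 15 nM in an assay on isolated protein for inhibition of Nicotinamide phosphoribosyltransferase (Homo sapiens), read by mass spectrometry, with stated times of 15 min and 30 min; on this read-out lower numbers stand for stronger inhibition and higher numbers for weaker inhibition.
Compound 2 `CC(=O)N1CCC(S(=O)(=O)c2ccc(CNC(=O)N3Cc4ccncc4C3)cc2)CC1`: 83 nM.

Compound 2 carries the highest of the two numbers in this assay. Going by the values given here, the single measured step, a 5.5-fold higher number from compound 1 to compound 2 (0.74 log units; beyond the scatter), concerns the same sulfonyl sulfur and was modest. Compound 3 `O=C(NCc1ccc(S(=O)(=O)N2CCC[C@@H](O)C2)cc1)N1Cc2ccncc2C1` differs from compound 2 by 3-hydroxypiperidin-1-yl in place of 1-acetylpiperidin-4-yl on a sulfonyl sulfur. Among the compounds with values here, no measured pair shows a hydroxypiperidinyl on that sulfur, so the step from compound 1 to compound 2 is the only guide, and it is indirect. Compound 3 is therefore expected to stay close, with an estimated step of a 1.4-fold higher number from compound 2 to compound 3 (0.16 log units; within the scatter) within the scatter. The estimate for compound 3 is 120 nM, range 40 nM to 400 nM.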

Compound 3, half-maximal inhibitory concentration: 28 nM
Compound 3: the middle estimate sits 4.3-fold (0.63 log units) above what was measured, and the stated range ends above it.
By their numbers in this assay, from the lowest: compounds 1 and 3 (each within the scatter of the next); then compound 2.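

With 3-hydroxypiperidin-1-yl on the sulfonyl sulfur, a non-aromatic ring is not separated from 5-(trifluoromethyl)pyridin-3-yl, at a 1.9-fold higher number from compound 1 to compound 3 (0.27 log units; within the scatter). The higher number of compound 2 therefore does not hold for every non-aromatic ring at this position, as a 3.0-fold lower number from compound 2 to compound 3 (0.47 log units; beyond the scatter) shows. No measurement available explains either step.

On these data alone, the contribution of the hydroxyl and its defined stereocentre stays open, and a plain piperidin-1-yl or the opposite stereoisomer would bear on it. Also open, as far as these compounds go, is how a morpholine or a ring carrying a carboxylic acid would read here.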